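The source may report more compounds than this note shows. Statements on the series, on what has been measured and on what is new or still open speak of the compounds shown alone.

Measured compounds:
- compound 1 `COc1ccc(-c2cc(COC(Cc3cn(C4CCN(Cc5ccc([N+](=O)[O-])cc5)CC4)nn3)c3ccc(Br)cc3)on2)cc1`: > 25000 nM
- compound 2 `O=[N+]([O-])c1ccc(CN2CCC(n3cc(CC(OCc4cc(-c5cccc(Br)c5)no4)c4ccc(Br)cc4)nn3)CC2)cc1`: > 25000 nM
- compound 3 `O=[N+]([O-])c1ccc(CN2CCC(n3cc(CC(OCc4cc(-c5cccc(F)c5)no4)c4ccc(Br)cc4)nn3)CC2)cc1`: 6000 nM

In a functional assay on HCT-116 cells (Homo sapiens) for cytotoxicity, with a stated time of 48 h (on this read-out higher numbers stand for weaker inhibition and lower numbers for stronger inhibition), compound 1 gives > 25000 nM, which is a limit of the assay and not a number. Compound 2 likewise gives > 25000 nM, again a limit. Within the data shown here, compound 3 gives 6000 nM, the only actual number among the three, so it stands as the one compound with a readable result. The step from compound 1 to compound 2 is a step that the two limits leave unreadable from compound 1 to compound 2. The other two steps are readable in one direction: an at least 4.1-fold lower number from compound 1 to compound 3 (0.61 log units; beyond the scatter) and an at least 4.1-fold lower number from compound 2 to compound 3 (0.61 log units; beyond the scatter), both bounded by the limit of > 25000 nM in this assay, at which 2 of the 3 values shown sit.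

Compound 4 `N#Cc1cccc(-c2cc(COC(Cc3cn(C4CCN(Cc5ccc([N+](=O)[O-])cc5)CC4)nn3)c3ccc(Br)cc3)on2)c1` differs from compound 3 in one place: cyano in place of fluoro on an aromatic carbon. Among the measured compounds shown here, none of the measured steps exchanges fluoro for cyano; the nearest comparison is the halogen exchange from compound 2 to compound 3, which lowered the number but only to the extent the limit allows reading. The data therefore give no direct guide to the size or direction of this particular change, and the expected step of a 1.3-fold higher number from compound 3 to compound 4 (0.12 log units; within the scatter) is taken as small. Compound 4 is accordingly estimated at 8000 nM, with a plausible range from 2500 nM to 25000 nM.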

Compound 4, half-maximal inhibitory concentration: > 25000 nM
Compound 4: a limit, no number (the forecaster's own chance of this, stated with the estimate: 30%); middle value at least 3.1-fold (0.49 log units) from the limit.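

In this assay, cyano in place of fluoro on this ring gives an at least 4.1-fold higher number from compound 3 to compound 4 (0.61 log units; beyond the scatter), so a second replacement for fluoro at this position, and this time not a halogen, also weakens the read-out. Compound 4 gives > 25000 nM, which is a limit of the assay and not a number. The 3-bromophenyl, 3-cyanophenyl and 4-methoxyphenyl compounds therefore cannot be ranked against each other, the steps among them cannot be read, and the 3-fluorophenyl of compound 3 remains the only ring here that gives a readable result: the limit of > 25000 nM in this assay, at which 3 of the 4 values shown sit.

As far as these compounds go, what stays open is whether fluoro is a special case at this position or whether other replacements would also give a readable number, as a 3-chlorophenyl, a 3-methylphenyl or a plain phenyl ring could show. From the compounds shown here alone, it is also open how an amine or a carboxylic acid would read in the same place, and whether any group here could take the number lower than that of compound 3.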